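Moving the Nitro Group Around the Outer Ring

The source may hold more compounds than are shown below. What is called first, only, known or untested is meant among the compounds shown, and "the series" means these compounds.

Among the compounds with values here, compound 2, `COc1cc(CC(O)c2ccc(-c3cccc([N+](=O)[O-])c3)cc2)c([N+](=O)[O-])cc1OC`, is one of two compounds measured in an ADME assay on HeLa Rh cells (Homo sapiens) for cytotoxicity, read by microscopy; on this read-out higher numbers stand for lower toxicity in this test and lower numbers for higher toxicity in this test; compound 2 gives 5500 nM, while compound 1, `COc1cc(CC(O)c2ccc(-c3ccc(C)cc3)cc2)c([N+](=O)[O-])cc1OC`, gives 4700 nM, and the two lie within the usual scatter of each other. Compound 3, `COc1cc(CC(O)c2ccc(-c3ccccc3[N+](=O)[O-])cc2)c([N+](=O)[O-])cc1OC`, differs from compound 2 only in 2-nitrophenyl in place of 3-nitrophenyl on an aromatic carbon. Within the data shown here, the single measured step, a 1.2-fold higher number from compound 1 to compound 2 (0.07 log units; within the scatter), altered the same outer ring and produced no shift beyond the scatter. The change toward compound 3 is therefore expected to amount to no change at the digits printed from compound 2 to compound 3 (within the scatter), again nothing beyond the scatter. Compound 3 is estimated at 5500 nM, with a range from 2500 nM to 12000 nM.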

Compound 3, half-maximal cytotoxic concentration: 9500 nM
Compound 3: middle estimate off by 1.7-fold (0.24 log units), on the low side; low and high end bracket the measured number.
By their numbers in this assay, from the lowest: compounds 1, 2 and 3 (each within the scatter of the next, the first and the last beyond it).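

Moving the nitro group on the outer ring gives a 1.7-fold higher number from compound 2 to compound 3 (0.24 log units; within the scatter) and so leaves 2-nitrophenyl and 3-nitrophenyl indistinguishable in this assay. This position does, however, now show its first step beyond the scatter: 2-nitrophenyl in place of 4-methylphenyl gives a 2.0-fold higher number from compound 1 to compound 3 (0.31 log units; beyond the scatter) and marks a modest shift toward lower toxicity in this test. No available evidence accounts for this difference. On these data alone, whether an amine or a carboxylic acid on the outer ring would shift the number further, and in which direction, remains open.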